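This account rests on a few compounds, and the source may have more. Where it says the series, first, only, none or still open, it means among the compounds named here.

In an in vitro ADME assay on microsomes from liver (Homo sapiens) for metabolic stability (a lower number here means slower removal, a higher number faster removal of the compound), compound 1 `Cc1ccc(C(=O)N2CCC(=CC(=O)N[C@@H]3CCN(Cc4ccc5cc(F)ccc5c4)C3)CC2)c(O)c1` gives 156 mL/min/kg as its clearance, and compound 2 `COc1ccc(C(=O)N2CCC(=CC(=O)N[C@@H]3CCN(Cc4ccc5cc(F)ccc5c4)C3)CC2)c(O)c1` gives 232 mL/min/kg on the same read-out. Among the measured compounds shown here, compound 2 therefore sits level with the only other measured compound, since the two numbers lie within the usual scatter of repeated measurements. Compound 3 `O=C(C=C1CCN(C(=O)c2ccc(Cl)cc2O)CC1)N[C@@H]1CCN(Cc2ccc3cc(F)ccc3c2)C1` keeps the shared core and alters one group of compound 2. The change reads chloro in place of methoxy on an aromatic carbon and in words it is chloro in place of methoxy on an aromatic carbon, meta to a hydroxy group, so 2-hydroxy-4-methoxyphenyl becomes 4-chloro-2-hydroxyphenyl. For the measured compounds named here, one measured step touches the same place, namely a 1.5-fold higher number from compound 1 to compound 2 (0.17 log units; within the scatter) with methoxy in place of methyl. Going by the values given here, no measured compound carries chloro there, so this single step is only a weak guide. Going by that step, no change beyond the scatter is expected in this assay for the new swap, in either direction. The estimated step is a 1.3-fold lower number from compound 2 to compound 3 (0.11 log units; within the scatter) and nothing larger is expected. For compound 3 the expected clearance is 180 mL/min/kg with an estimated range from 95 mL/min/kg to 330 mL/min/kg as the likely span.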

Compound 3, clearance: 87 mL/min/kg
Beside the measured number, compound 3's estimate is 2.1-fold (0.32 log units) above it; the measured number lies below the stated range.
By their numbers in this assay, from the lowest: compounds 3, 1 and 2 (each within the scatter of the next, the first and the last beyond it).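

In this assay, the ring position that lies meta to a hydroxy group and para to a large group now shows a step beyond the scatter: swapping methoxy for chloro gives a 2.7-fold lower number from compound 2 to compound 3 (0.43 log units; beyond the scatter) in this modest change, whereas the earlier swap of methyl for methoxy at this position stayed within the scatter. Chloro in place of methyl gives a 1.8-fold lower number from compound 1 to compound 3 (0.25 log units; within the scatter) and also stays within the scatter, so chloro stands clearly apart only from methoxy and not from methyl among these three groups. No measurement shown here explains this difference between chloro and methoxy.

The compounds shown leave open how a fluoro, a trifluoromethyl, a nitrile or an amine would read at this same position, so three groups give only a thin picture of what the position tolerates. Going by these compounds, all three compounds also carry the same hydroxy group on the ring, and it remains open whether chloro and methoxy would differ in the same way with a methoxy or a plain hydrogen in its place.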